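Putting a methyl on a hydroxy group

The source may report more compounds than this note shows. Statements on the series, on what has been measured and on what is new or still open speak of the compounds shown alone.

Within the data shown here, in a functional assay on MDA-MB-231 cells (Homo sapiens) for cytotoxicity, read by sulforhodamine B assay, with a stated time of 48 h (on this read-out lower numbers stand for stronger inhibition of growth and higher numbers for weaker inhibition of growth), compound 1 (`COc1cc(C(=O)c2ccc(OC)c(O)c2OC)cc(OC)c1O`) gives 2160 nM and stands lowest of the two compounds measured so far. Compound 2 (`COc1cc(C(=O)c2ccc3c(c2)oc(=O)n3S(C)(=O)=O)cc(OC)c1OC`) gives 4850 nM as the higher number, a gap beyond the usual scatter. Compound 3 (`COc1ccc(C(=O)c2cc(OC)c(OC)c(OC)c2)c(OC)c1O`) turns a hydroxy into a methoxy: methyl in place of hydrogen on an oxygen on an aromatic ring is the whole difference, methyl in place of hydrogen on an oxygen on an aromatic ring. In this assay, among the measured compounds shown here, no measured pair shows this change, so the expectation is loose. A moderate move toward stronger inhibition is expected, estimated as a 5.4-fold lower number from compound 1 to compound 3 (0.73 log units; beyond the scatter) and uncertain. The estimate for compound 3 is 400 nM (expected range 60 nM to 2500 nM).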

Compound 3, concentration for 50% growth inhibition: 24.6 nM
Beside the measured number, compound 3's estimate is 16-fold (1.21 log units) above it, and the stated range ends above it.
By their numbers in this assay, from the lowest: compound 3; then compound 1; then compound 2.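

Adding one methyl to the hydroxy group in this assay gives an 88-fold lower number from compound 1 to compound 3 (1.94 log units; beyond the scatter) and so shows, as no earlier pair could, that this one oxygen position strongly affects growth inhibition. The change adds just one carbon, yet the step is large and well beyond the usual scatter. Nothing available explains why so small a change has so large an effect. The compounds shown leave open whether an ethyl group or a longer chain on this oxygen would give a similar step. They also leave open what an amine in place of the hydroxy would do.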